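A Single Fluoro Added to Compound 1

The compounds below may be only part of what the source reports. "The series", "measured", "known", "first", "only" and "open" are said of these compounds alone.

Compound 1 `CC1CCN(C2CCN(S(=O)(=O)c3cccnc3)CC2)CC1` is the weaker of two compounds measured in a functional assay on DLD-1 cells (Homo sapiens) for antiproliferative activity, read by CellTiter-Glo, with a stated time of 72 h; a lower number here means a stronger inhibitor, a higher number a weaker inhibitor: compound 1 gives 2400 nM, whereas compound 2 `CC1CCN(C2CCN(S(=O)(=O)c3ccc(Br)cc3OC(F)(F)F)CC2)CC1` gives 5 nM, a far lower number. Compound 2 differs from compound 1 in several places, so no single change can be credited for that gap. Compound 3 `CC1CCN(C2CCN(S(=O)(=O)c3cccnc3F)CC2)CC1` differs from compound 1 in one place only: fluoro in place of hydrogen on an aromatic carbon, sitting next to the ring nitrogen. Since fluoro is a small addition, the expected step is modest, a 2.0-fold lower number from compound 1 to compound 3 (0.30 log units; within the scatter), probably toward a lower number. Compound 3 is estimated at 1200 nM, within 300 nM to 4000 nM.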

Compound 3, half-maximal inhibitory concentration: > 5000 nM
Compound 3 ended at the assay's limit; the forecaster's own chance of this, stated with the estimate: 5%; middle value at least 4.1-fold (0.61 log units) away from the limit.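

In this assay, the change to 2-fluoropyridin-3-yl brings no gain: the step is an at least 2.0-fold higher number from compound 1 to compound 3 (0.31 log units; beyond the scatter). Even a single fluoro, next to the ring nitrogen and ortho to a large group, thus moves the number upward from an already weak compound. Compound 3 stands at a limit of the assay, so the full size of this step stays unknown: the limit of > 5000 nM in this assay, at which 1 of the 3 values shown sits.

The compounds shown leave open whether this loss belongs to fluoro itself or to any group at this position. A methyl group or an amine here would help to separate the two.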